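Trifluoromethyl for Methyl on Two Differently Joined Cores

The source may report more compounds than this note shows. Statements on the series, on what has been measured and on what is new or still open speak of the compounds shown alone.

Measured in an assay on isolated protein for inhibition of Amine oxidase [flavin-containing] B (Homo sapiens), read by Amplex Red, with a stated time of 15 min; a lower number here means a stronger inhibitor, a higher number a weaker inhibitor:
Compound 1, `CC(=O)c1ccc(OCc2cccc(C)c2)cc1`: 86.3 nM
Compound 2, `CC(=O)c1ccc(OCc2cccc(C(F)(F)F)c2)cc1`: 58.2 nM
Compound 3, `CC(=O)c1cccc(OCc2cccc(C)c2)c1`: 893 nM

Compound 3 has the same atoms as compound 1, joined differently; the difference between the two cores is not broken down here, and compound 3 gives the highest of the three numbers. Compound 1 and compound 2 differ by trifluoromethyl in place of methyl on an aromatic carbon, and that change gave a 1.5-fold lower number from compound 1 to compound 2 (0.17 log units; within the scatter). Compound 4, `CC(=O)c1cccc(OCc2cccc(C(F)(F)F)c2)c1`, has not yet been measured. It differs from compound 3 by trifluoromethyl in place of methyl on an aromatic carbon, the same change at the same place. For the measured compounds named here, since the one earlier instance gave a 1.5-fold lower number from compound 1 to compound 2 (0.17 log units; within the scatter), a step of similar size is expected for compound 4, a 1.5-fold lower number from compound 3 to compound 4 (0.17 log units; within the scatter). In this assay compound 4 is therefore estimated at about 600 nM, most likely between 300 nM and 1200 nM.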

Compound 4, half-maximal inhibitory concentration: 21.2 nM
Beside the measured number, compound 4's estimate is 28-fold (1.45 log units) above it; measured number outside the range, below it.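

In this assay the change from methyl to trifluoromethyl did not carry over from one core to the other at a constant size: the same change on two cores in this assay, a 1.5-fold lower number (0.17 log units; within the scatter) from compound 1 to compound 2 and a 42-fold lower number (1.62 log units; beyond the scatter) from compound 3 to compound 4, 28-fold (1.45 log units) apart, beyond the scatter of two such steps. The change gave a 42-fold lower number from compound 3 to compound 4 (1.62 log units; beyond the scatter) and so did far more on the core of compound 3 than on the core of compound 1, which means that the size of this step depends on the core in this series. These two pairs do not show why the cores differ, and they give no rule for any further core. The compounds shown leave open how a nitrile or a chlorine in place of the methyl would behave on the two cores. They also leave open whether the core dependence would persist if the acetyl group gave way to an amide.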